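The source may report more compounds than this note shows. Statements on the series, on what has been measured and on what is new or still open speak of the compounds shown alone.

Two compounds sharing one core have been examined in an ADME assay on Huh-7 cells (Homo sapiens) for cytotoxicity, read by MTT assay; a higher number here means that more compound is tolerated, a lower number that less compound is tolerated. Compound 1 `C[C@H]1CC[C@H](Cn2cnc(=O)c3cc(Oc4ncccc4C(F)(F)F)ccc32)CC1` carries a 4-methylcyclohexyl group on a saturated chain carbon bound to an aromatic nitrogen. In this assay compound 1 reaches only a limit, > 10 uM. Compound 2 `Cn1cnc(=O)c2cc(Oc3ncccc3C(F)(F)F)ccc21` has a hydrogen in place of 4-methylcyclohexyl on a saturated chain carbon bound to an aromatic nitrogen. In this assay compound 2 likewise gives only a limit, > 10 uM. The step that the two limits leave unreadable from compound 1 to compound 2 therefore has no readable size. Compound 2 thus stands at the limit of this assay, without a number of its own; what the pair shows is the limit of > 10 uM in this assay, at which 2 of the 2 values shown sit.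

Compound 3 `O=c1ncn(Cc2ccccc2)c2ccc(Oc3ncccc3C(F)(F)F)cc12` differs from compound 2 by phenyl in place of hydrogen on a saturated chain carbon bound to an aromatic nitrogen. Among the measured compounds shown here, because a step that the two limits leave unreadable from compound 1 to compound 2 cannot be read, no measured step gives a size to lean on in this assay; the one observation is the limit of > 10 uM in this assay, at which 2 of the 2 values shown sit. Compound 3 is therefore expected to sit at the limit as well, with a step that the limit leaves unreadable from compound 2 to compound 3 expected to stay within the scatter. Compound 3 is estimated at 15 uM, in the range 7 uM to 40 uM.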

Compound 3, half-maximal toxic concentration: > 10 uM
Compound 3 gave a limit, no number (the forecaster's own chance of this, stated with the estimate: 75%); the middle value does not contradict the limit.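

In this assay compound 3 gives > 10 uM, a limit and not a number. The steps among compound 1, compound 2 and compound 3 therefore cannot be read: the limit of > 10 uM in this assay, at which 3 of the 3 values shown sit. Going by these compounds, what stays open is the actual tolerated concentration of each of the three compounds, and so whether exchanging these groups changes it at all.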